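A few compounds are considered here, and "the series" means these few. Any claim that something is new, unique, unknown or untested is made for them only; others in the source may bear on it.

Measured compounds:
compound 1 `COc1ccc(Cn2cc(/C=N\NC(=O)c3c[nH]c4ccccc34)c3cc(OC)ccc32)cc1`, 9800 nM
compound 2 `COc1ccc(Cn2cc(/C=N\NC(=O)c3c[nH]c4ccc(Br)cc34)c3cc(OC)ccc32)cc1`, 61200 nM
compound 3 `COc1ccc(Cn2cc(/C=N\NC(=O)c3c[nH]c4ccc(Br)cc34)c3ccc(F)cc32)cc1`, 99800 nM

These three were tested in a functional assay on MDA-MB-231 cells (Homo sapiens) for cytotoxicity; on this read-out higher numbers stand for weaker inhibition and lower numbers for stronger inhibition. Compound 2 and compound 1 differ in one place, (hydrogen in place of bromo on an aromatic carbon), and this gave a 6.2-fold lower number from compound 2 to compound 1 (0.80 log units; beyond the scatter). Compound 3 and compound 2 share the bromo group but have different cores; the difference between the two cores is not broken down here. Compound 4 `COc1ccc(Cn2cc(/C=N\NC(=O)c3c[nH]c4ccccc34)c3ccc(F)cc32)cc1` has not yet been measured. It differs from compound 3 by hydrogen in place of bromo on an aromatic carbon, the same change as from compound 2 to compound 1, at a place described in the same words. Because a 6.2-fold lower number from compound 2 to compound 1 (0.80 log units; beyond the scatter) was a modest step beyond the scatter, a step of similar size is expected for compound 4, a 5.9-fold lower number from compound 3 to compound 4 (0.77 log units; beyond the scatter). Compound 4 is therefore estimated at 17000 nM, likely between 6000 nM and 50000 nM.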

Compound 4, half-maximal inhibitory concentration: 71200 nM
Compound 4: the middle estimate sits 4.2-fold (0.62 log units) below what was measured; measured number outside the range, above it.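

Swapping the bromo for hydrogen on the core of compound 3 gave a 1.4-fold lower number from compound 3 to compound 4 (0.15 log units; within the scatter) in this assay, so the clear gain seen on the core of compound 1 did not carry over: the same change on two cores in this assay, a 6.2-fold lower number (0.80 log units; beyond the scatter) from compound 2 to compound 1 and a 1.4-fold lower number (0.15 log units; within the scatter) from compound 3 to compound 4, 4.5-fold (0.65 log units) apart, beyond the scatter of two such steps In this series, then, the size of a step measured on one core is not a safe guide to the same change on another. These two cores show only that the outcome can depend on the core; they give no general rule and do not explain the difference.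

Still open, on these data alone, is how the change from 5-bromo-1H-indol-3-yl to 1H-indol-3-yl behaves on further cores. Also open, as far as these compounds go, is what other groups at the same place, such as an amine or a carboxylic acid, would do on each core.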